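Aryl Returns to the Ring Nitrogen: Compound 4 Expected Level with Compound 3

The compounds below may be only part of what the source reports. "The series", "measured", "known", "first", "only" and "open" are said of these compounds alone.

Measured compounds:
Compound 1, `Nc1scc(CN2CCN(c3cccc(Cl)c3Cl)CC2)c1C(=O)c1ccc(Cl)cc1` — 0%
Compound 2, `Nc1scc(CN2CCN(c3ccc(OC(F)(F)F)cc3)CC2)c1C(=O)c1ccc(Cl)cc1` — 1%
Compound 3, `Nc1scc(CN2CCN(C3CCCCCC3)CC2)c1C(=O)c1ccc(Cl)cc1` — 0%

Of the compounds shown here, three sharing one core have been tested in an assay on CHO cells for displacement of a labelled ligand from adenosine receptor A3 (Homo sapiens), read by scintillation counting, with a stated time of 120 min, tested at 10 uM; a lower number here means less inhibition, a higher number more inhibition at the concentration tested (going by the name of the read-out). In this assay compound 1 gives 0%, compound 2 gives 1% and compound 3 gives 0%. Compound 3 stands level with compound 1 at the digits printed, the two together being the lowest of the three numbers; its nearest neighbour is compound 1 with no change at the digits printed from compound 1 to compound 3 (within the scatter), and its furthest is compound 2 with a number 1 percentage points lower from compound 2 to compound 3 (within the scatter). None of these steps leaves the scatter.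

Compound 4, `Nc1scc(CN2CCN(c3cc(F)cc(F)c3)CC2)c1C(=O)c1ccc(Cl)cc1`, is the next compound. Its difference from compound 3 is 3,5-difluorophenyl in place of cycloheptyl on an amine nitrogen in a ring.

Among the compounds with values here, two measured steps bear on this change, since both exchange an aromatic ring for the cycloheptyl group or the reverse on the same ring nitrogen: no change at the digits printed from compound 1 to compound 3 (within the scatter) and a number 1 percentage points lower from compound 2 to compound 3 (within the scatter). Both are within the scatter, and the whole set of three numbers lies at the floor of the read-out. The return from cycloheptyl to an aromatic ring is therefore expected to produce no step beyond the scatter, with a number 1 percentage points higher from compound 3 to compound 4 (within the scatter) as the estimated change. Compound 4 is expected to give 1% in this assay, within a range from -8% to 10%.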

Compound 4, a percentage reported as inhibition, at one concentration (the size of the read-out at that concentration, not a potency): 2%
Compound 4: the middle estimate sits 1 percentage points below what was measured, within the range that was stated.
By their numbers in this assay, from the lowest: compounds 1, 3, 2 and 4 (each within the scatter of the next).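

In this assay, the 3,5-difluorophenyl group on the amine nitrogen in a ring brings a further aromatic ring into the set at this position, and none of its comparisons leaves the scatter, with a number 2 percentage points higher from compound 3 to compound 4 (within the scatter), a number 1 percentage points higher from compound 2 to compound 4 (within the scatter) and a number 2 percentage points higher from compound 1 to compound 4 (within the scatter). Fluorine substituents, which none of the earlier compounds carried, therefore leave compound 4 inseparable from the compounds bearing 2,3-dichlorophenyl, 4-(trifluoromethoxy)phenyl or cycloheptyl at this nitrogen. No measurement is available to explain this flat result.

With all four numbers at the floor of the read-out, the compounds shown leave open whether any group on this ring nitrogen can raise inhibition at the concentration tested, for example a benzyl group, a pyridine ring or a longer chain such as hexyl. They also leave open whether a change elsewhere on the shared core, such as a carboxylic acid or a further amine, would lift the number off that floor.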